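A few compounds are considered here, and "the series" means these few. Any claim that something is new, unique, unknown or untested is made for them only; others in the source may bear on it.

Measured compounds:
compound 1 `COc1cc(-c2cc(/C=C/C(=O)c3ccc(N)cc3)[nH]n2)cc(OC)c1OC`, -22%
compound 2 `COc1ccc(-c2cc(/C=C/C(=O)c3ccc(OC)c(OC)c3)[nH]n2)cc1`, -39%

In a functional assay on CCRF-CEM cells (Homo sapiens) for cytotoxicity, read by sulforhodamine B assay, with a stated time of 48 h, tested at 10 uM (on this read-out lower numbers stand for a stronger effect and higher numbers for a weaker effect at the one concentration tested), compound 1 gives -22%. Of the two numbers shown, compound 1 stands highest; the nearest is compound 2, which gives -39% in this assay, a number that sits lower than that of compound 1 by a gap beyond the usual scatter. Within the data shown here, no pair of measured compounds differing in a single place is available, so no measured step guides the way from compound 1 onward.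

The account now turns to compound 3 `COc1cc(-c2cc(/C=C/C(=O)c3ccc(Cl)c(Cl)c3)[nH]n2)cc(OC)c1OC`, which is not yet measured in this assay. Its structure departs from that of compound 1 in one spot: 3,4-dichlorophenyl in place of 4-aminophenyl on a carbonyl carbon.

Among the measured compounds shown here, with no measured step of this kind to lean on, only a modest shift is expected from compound 1 to compound 3 in this assay, and its direction is uncertain; the expected step of a number 8 percentage points lower from compound 1 to compound 3 (within the scatter) points slightly downward but could well fall within the scatter. Compound 3 is therefore estimated to give -30% in this assay, with a range from -65% to 5%.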

Compound 3, a percentage reported as activity, at one concentration (the size of the read-out at that concentration, not a potency): 9%
Compound 3: middle estimate off by 39 percentage points, on the low side; measured number above the stated range.
By their numbers in this assay, from the lowest: compound 2; then compound 1; then compound 3.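

Among these compounds, this is the first change at a single place that can be read in this assay: putting 3,4-dichlorophenyl in place of 4-aminophenyl on a carbonyl carbon gives a number 31 percentage points higher from compound 1 to compound 3 (beyond the scatter), so the group at this position clearly matters for the effect at the one concentration tested. The change runs toward a weaker effect, and the sign of the read-out flips, since compound 1 gives -22% and compound 3 gives 9%. The exchange removes the hydrogen-bond donor and acceptor counted on 4-aminophenyl and brings two chlorine atoms, but nothing measured here explains why the number moves, and no supporting data bear on the cause.

Since the amine leaves and both chlorine atoms enter in one step, the compounds shown do not tell whether the loss of the amine, the arrival of the chlorine atoms, or both together account for the shift. Also open, on these data alone, is whether an unsubstituted phenyl, or a phenyl carrying a single chlorine or a hydroxyl, on that carbonyl carbon would give a number closer to that of compound 1 or to that of compound 3.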